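A few compounds are considered here, and "the series" means these few. Any claim that something is new, unique, unknown or untested is made for them only; others in the source may bear on it.

Working notes on the series.

The shared core carries an acetyl, a phenol and a chain ending in a nitrile; the compounds differ in the substituent on the saturated chain carbon bound to an aromatic carbon. In an assay on isolated protein for binding affinity to leukotriene B4 receptor 1 (Homo sapiens), tested at 1 uM (on this read-out lower numbers stand for less inhibition and higher numbers for more inhibition at the one concentration tested (going by the name of the read-out)), compound 1 `CC(=O)c1cc(C)c(OCCCCC#N)cc1O` gives 35%, compound 2 `CCc1cc(C(C)=O)c(O)cc1OCCCCC#N` gives 57% and compound 3 `C=CCc1cc(C(C)=O)c(O)cc1OCCCCC#N` gives 57%. The measured steps are a number 22 percentage points higher from compound 1 to compound 2 (beyond the scatter) and a number 22 percentage points higher from compound 1 to compound 3 (beyond the scatter), while no change at the digits printed from compound 2 to compound 3 (within the scatter). Compound 3 therefore stands level with compound 2 at the digits shown, the two together being the highest of the three numbers, and is set apart from compound 1 only.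

Compound 4 `C=CCCCCOc1cc(O)c(C(C)=O)cc1CC=C` differs from compound 3 at the far end of the chain: vinyl in place of cyano on a saturated chain carbon, four bonds along the chain from an oxygen on an aromatic ring. Among the compounds with values here, none of the measured steps touches this position; all three concern the substituent on the saturated chain carbon bound to an aromatic carbon, so no measured step bears directly on the change. With no guidance from the data, the expected step is a number 2 percentage points lower from compound 3 to compound 4 (within the scatter), that is, none beyond the scatter, with a wide range to allow for either direction. For compound 4 the estimated value in this assay is 55%, in the range 35% to 75%.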

Compound 4, a percentage reported as inhibition, at one concentration (the size of the read-out at that concentration, not a potency): 27%
Compound 4: the middle estimate sits 28 percentage points above what was measured; measured number below the stated range.
By their numbers in this assay, from the lowest: compounds 4 and 1 (each within the scatter of the next); then compounds 2 and 3 (each within the scatter of the next).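

Within the data shown here, the far end of the chain matters in a way the earlier compounds could not show: in this assay, vinyl in place of cyano on a saturated chain carbon, four bonds along the chain from an oxygen on an aromatic ring, goes with a number 30 percentage points lower from compound 3 to compound 4 (beyond the scatter). The two groups match in heavy atom count and neither carries a ring, yet they are not interchangeable here; cyano brings a nitrogen, a triple bond and a hydrogen-bond acceptor, while vinyl brings a double bond and no acceptor. The data give no measured basis for saying which of these differences accounts for the step, and no explanation for it can be offered.

Going by these compounds, it remains open whether the nitrile itself is what counts at this position, since an amide, a carboxylic acid, a primary amine or a longer chain ending in a nitrile would each separate the identity of the end group from its distance along the chain. On these data alone, it also remains open whether the swap from cyano to vinyl carries the same step on the cores of compound 1 and compound 2, where the substituent on the saturated chain carbon bound to an aromatic carbon differs.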